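A few compounds are considered here, and "the series" means these few. Any claim that something is new, unique, unknown or untested is made for them only; others in the source may bear on it.

Within the data shown here, compound 2 `O=C1CCc2cc(-n3cnnc3)ccc2N1Cc1ccc(Cl)cc1Cl` gives 300 mg/kg in a functional assay on the whole organism (strain KunMing) with Mus musculus as the target, in the maximal electroshock model, with a stated time of 0.5 h (on this read-out higher numbers stand for an effect only at larger amounts of compound and lower numbers for an effect already at smaller amounts), the highest of the two numbers known so far; compound 1 `CCCCCCN1C(=O)CCc2cc(-n3cnnc3)ccc21` gives 100 mg/kg in this assay. Compound 3 `CCCCCCCN1C(=O)CCc2cc(-n3cnnc3)ccc21` carries hexyl in place of 2,4-dichlorophenyl on a saturated chain carbon bound to an amide-type nitrogen in a ring. Among the measured compounds shown here, the one step that bears on this change is the reverse of it: a 3.0-fold higher number from compound 1 to compound 2 (0.48 log units; beyond the scatter), the hexyl of compound 3 being one carbon longer than the pentyl of compound 1. A step of about that size, downward, is therefore expected, a 3.0-fold lower number from compound 2 to compound 3 (0.48 log units; beyond the scatter). Compound 3 is expected to give about 100 mg/kg in this assay, with a range from 50 mg/kg to 200 mg/kg.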

Compound 3, minimum effective dose: 300 mg/kg
Compound 3: middle estimate off by 3.0-fold (0.48 log units), on the low side; the measured number lies above the stated range.
By their numbers in this assay, from the lowest: compound 1; then compounds 2 and 3 (each within the scatter of the next).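

Hexyl in place of 2,4-dichlorophenyl brings no change at the digits printed from compound 2 to compound 3 (within the scatter) in this assay, so at this place a chain can read the same as the dichlorinated ring. A methyl in place of hydrogen on the chain, six bonds along from the amide-type nitrogen, brings a 3.0-fold higher number from compound 1 to compound 3 (0.48 log units; beyond the scatter) and so separates two chains that differ by a single carbon. Nothing measured here accounts for this. Open, on these data alone, is whether butyl, octyl or a chain ending in an amine would read lower than compound 1 or higher than compound 3.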